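Three Replacements at One Position of a Shared Core

The compounds below may be only part of what the source reports. "The series", "measured", "known", "first", "only" and "open" are said of these compounds alone.

Measured so far:
Compound 1, `COc1ccc(CN(C(=O)Cn2cc(COc3ccc4ccc(=O)oc4c3)nn2)c2cc(OC)c(OC)c(OC)c2)cc1`: 860 nM
Compound 2, `COc1ccc(CN(C(=O)Cn2cc(CSc3nc4ccccc4s3)nn2)c2cc(OC)c(OC)c(OC)c2)cc1`: 28500 nM
Compound 3, `COc1ccc(CN(C(=O)Cn2cc(CSc3nncs3)nn2)c2cc(OC)c(OC)c(OC)c2)cc1`: 16500 nM

In a functional assay on PC-3 cells (Homo sapiens) for antiproliferative activity, read by MTT assay, with a stated time of 48 h (on this read-out lower numbers stand for stronger inhibition and higher numbers for weaker inhibition), compound 1 gives 860 nM, the lowest of the three numbers. The two measured steps away from it are both large: a 33-fold higher number from compound 1 to compound 2 (1.52 log units; beyond the scatter) and a 19-fold higher number from compound 1 to compound 3 (1.28 log units; beyond the scatter). Between the two weaker compounds, a 1.7-fold lower number from compound 2 to compound 3 (0.24 log units; within the scatter).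

Compound 4, `COc1ccc(CN(C(=O)Cn2cc(CNS(=O)(=O)c3ccc(C)cc3)nn2)c2cc(OC)c(OC)c(OC)c2)cc1`, has not been measured. It differs from compound 1 at the same place that compounds 2 and 3 do: a group of 11 heavy atoms (7 carbon, 1 nitrogen, 2 oxygen, 1 sulfur; one six-membered aromatic ring of carbon only) in place of a group of 12 heavy atoms (9 carbon, 3 oxygen; one six-membered aromatic ring of carbon only, one six-membered aromatic ring with 1 hetero atom), on a saturated chain carbon bound to an aromatic carbon. Both measured exchanges at this place cost a lot, so the step to compound 4 is expected to go in the same direction, a higher number, though the entering group here carries one hydrogen-bond donor and no second ring, so its size is uncertain. In this assay compound 4 is expected to give about 9000 nM, within 2500 nM to 30000 nM, an estimated 10-fold higher number from compound 1 to compound 4 (1.02 log units; beyond the scatter).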

Compound 4, half-maximal inhibitory concentration: 12400 nM
Compound 4: the middle estimate sits 1.4-fold (0.14 log units) below what was measured; the measured number falls inside the stated range.
By their numbers in this assay, from the lowest: compound 1; then compounds 4, 3 and 2 (each within the scatter of the next, the first and the last beyond it).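

With ((4-methylphenyl)sulfonyl)amino on the saturated chain carbon, the loss in this assay extends beyond the two sulfanyl groups with hetero-atom rings: the new group, which carries a hydrogen-bond donor, still gives a 14-fold higher number from compound 1 to compound 4 (1.16 log units; beyond the scatter) and leaves compound 1 alone at the low end of the series. Set against the sulfanyl compounds, the result shows a 1.3-fold lower number from compound 3 to compound 4 (0.12 log units; within the scatter) within the scatter, while a 2.3-fold lower number from compound 2 to compound 4 (0.36 log units; beyond the scatter) is a modest step beyond it. Nothing shown here accounts for these differences. All the groups shown at this place contain a ring, so the effect of a simple amine, a carboxylic acid or a longer chain on the saturated chain carbon remains open. Which part of the group in compound 1 goes with its lower number also remains open.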